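Methoxy step from compound 3 to compound 4

This account rests on a few compounds, and the source may have more. Where it says the series, first, only, none or still open, it means among the compounds named here.

Compound 3 `Cc1ccccc1Nc1nc(C)c(C(=O)/C=C/c2ccccc2)s1` stands at the limit of a functional assay on Bel-7402 cells (Homo sapiens) for cytotoxicity, read by MTT assay; on this read-out lower numbers stand for stronger inhibition and higher numbers for weaker inhibition: compound 3 gives > 25000 nM, which is a limit of the assay and not a number. Compound 2 `Cc1ccccc1Nc1nc(C)c(C(=O)/C=C/c2ccc(Cl)cc2)s1` gives > 25000 nM, also a limit. Compound 1 `COc1cccc(/C=C/C(=O)c2sc(Nc3ccc(Cl)cc3)nc2C)c1` gives > 25000 nM, again a limit. The step that the two limits leave unreadable from compound 2 to compound 3 is therefore of unreadable size, and the limit of > 25000 nM in this assay, at which 3 of the 3 values shown sit, covers every value obtained so far. Compound 4 `COc1cccc(/C=C/C(=O)c2sc(Nc3ccccc3C)nc2C)c1` differs from compound 3 by methoxy in place of hydrogen on an aromatic carbon. Within the data shown here, compound 1 already carries this methoxy on the same ring and sits at the limit, so no measured step points to a shift beyond the scatter; the step that the limit leaves unreadable from compound 3 to compound 4 is expected to stay within it. Compound 4 is thus estimated at 35000 nM, with a range from 15000 nM to 100000 nM, most likely reported as a limit once more.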

Compound 4, half-maximal inhibitory concentration: > 25000 nM
Compound 4: a limit, no number; the forecaster's own chance of this, stated with the estimate: 85%; the middle value does not contradict the limit.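

Compound 4 gives > 25000 nM, a limit and not a number. No step among compound 1, compound 2, compound 3 and compound 4 can be read: the limit of > 25000 nM in this assay, at which 4 of the 4 values shown sit.

The compounds shown leave open whether any change on the shared core shifts inhibition at all.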